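Fluorinated Ester Analogue Against Dipeptidyl Peptidase 9

The compounds below may be only part of what the source reports. "The series", "measured", "known", "first", "only" and "open" are said of these compounds alone.

Measured so far:
Compound 1 `CC#CCn1c(N2CCC[C@@H](N)C2)nc2c1c(=O)n(Cc1ccc(Br)cc1C(=O)OCC)c(=O)n2C`: in an ADME assay on isolated protein for inhibition of Dipeptidyl peptidase 9 (Homo sapiens), with stated times of 15 min, 60 s and 20 min (a higher number here means a weaker inhibitor, a lower number a stronger inhibitor), compound 1 gives > 100000 nM, a limit of the assay rather than a number.
Compound 2 `CC#CCn1c(N2CCC[C@@H](N)C2)nc2c1c(=O)n(Cc1ccccc1C(=O)OC)c(=O)n2C`: in this assay compound 2 gives > 100000 nM, again a limit.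
Compound 3 `CC#CCn1c(N2CCC[C@@H](N)C2)nc2c1c(=O)n(Cc1ccc(Br)cc1C(=O)O)c(=O)n2C`: in this assay compound 3 gives > 100000 nM, also a limit.

All three share one core and differ only in the group carried on a saturated chain carbon bound to an aromatic nitrogen. Compound 3 stands at the limit, and so do the two others. Every measured step is unreadable: a step that the two limits leave unreadable from compound 1 to compound 2, a step that the two limits leave unreadable from compound 1 to compound 3 and a step that the two limits leave unreadable from compound 2 to compound 3. The reason is the limit of > 100000 nM in this assay, at which 3 of the 3 values shown sit.

Compound 4 `CC#CCn1c(N2CCC[C@@H](N)C2)nc2c1c(=O)n(Cc1cccc(F)c1C(=O)OC)c(=O)n2C` is the next candidate. Its difference from compound 3 is 3-fluoro-2-(methoxycarbonyl)phenyl in place of 4-bromo-2-carboxyphenyl on a saturated chain carbon bound to an aromatic nitrogen. The step from compound 2 to compound 3 bears most directly on this change, since it too swaps an ester for the acid on that phenyl group, but it is unreadable. For the measured compounds named here, no measured step gives a direction or a size, and nothing in the data suggests the fluorine or the methyl ester should pull the value into the measurable range.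

Compound 4 is therefore expected to sit at the limit as well, estimated at 200000 nM within 50000 nM to 1000000 nM. The expected step from compound 3 is a step that the limit leaves unreadable from compound 3 to compound 4, which cannot be read against a limit.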

Compound 4, half-maximal inhibitory concentration: > 100000 nM
Compound 4: only a limit was reported (the forecaster's own chance of this, stated with the estimate: 85%); the middle value is on the limit's open side.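

For the compounds shown here, no step from compound 4 to compound 1, compound 2 or compound 3 can be read, as all four compounds stand at a limit of the assay rather than at a number: the limit of > 100000 nM in this assay, at which 4 of the 4 values shown sit. The compounds shown leave open whether any group at this place on the shared core gives a readable value in this assay, and how fluoro, ester and acid compare.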